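This account rests on a few compounds, and the source may have more. Where it says the series, first, only, none or still open, it means among the compounds named here.

Measured compounds in a functional assay on U-118-MG cells (Homo sapiens) for cytotoxicity, read by MTT assay, with a stated time of 48 h; on this read-out higher numbers stand for weaker inhibition and lower numbers for stronger inhibition:
- compound 1 `CCOC(=O)C[n+]1cccc(O)c1`: > 200000 nM
- compound 2 `O=C(O[C@H]1C[C@H](n2cc(F)c(=O)[nH]c2=O)O[C@@H]1COP(=O)(O)Oc1cccnc1)c1ccccc1`: 920 nM
- compound 3 `O=C(O[C@H]1C[C@H](n2cc(F)c(=O)[nH]c2=O)O[C@@H]1COP(=O)(O)Oc1ccc2ncccc2c1)c1ccccc1`: 790 nM

The value for compound 1 is a limit of the assay, not a number (the limit of > 200000 nM in this assay, at which 1 of the 3 values shown sits). Among the two numbers, compound 2 holds the higher one; its nearest neighbour is compound 3, and the step of a 1.2-fold lower number from compound 2 to compound 3 (0.07 log units; within the scatter) lies within the scatter, so the two cannot be ordered.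

Compound 4 `C[N+]1(C)CCC(OP(=O)([O-])OC[C@H]2O[C@@H](n3cc(F)c(=O)[nH]c3=O)C[C@@H]2OC(=O)c2ccccc2)CC1` is not yet measured. It differs from compound 2 as follows: a group of 12 heavy atoms (7 carbon, 1 nitrogen, 3 oxygen, 1 phosphorus; one six-membered non-aromatic ring with 1 hetero atom) in place of a group of 10 heavy atoms (5 carbon, 1 nitrogen, 3 oxygen, 1 phosphorus; one six-membered aromatic ring with 1 hetero atom), on an oxygen on a saturated carbon. Among the measured compounds shown here, the only measured step that touches the same oxygen is a 1.2-fold lower number from compound 2 to compound 3 (0.07 log units; within the scatter), which swaps one aromatic group for another and moves nothing beyond the scatter. For the measured compounds named here, the change to compound 4 replaces the aromatic ring by a non-aromatic one and removes the hydrogen-bond donor, a kind of change for which no step is available here, so the expectation rests on the single step alone and carries a wide range.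

For compound 4 the expected step of a 1.3-fold higher number from compound 2 to compound 4 (0.12 log units; within the scatter) is taken as none beyond the scatter, with the range widened. The estimate for compound 4 is 1200 nM, between 350 nM and 4500 nM.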

Compound 4, half-maximal inhibitory concentration: 4420 nM
Compound 4: the middle estimate sits 3.7-fold (0.57 log units) below what was measured; measured number inside the range.
By their numbers in this assay, from the lowest: compounds 3 and 2 (each within the scatter of the next); then compound 4. At a limit, above all of these: compound 1.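

In this assay, among the compounds shown here, there is a 4.8-fold higher number from compound 2 to compound 4 (0.68 log units; beyond the scatter), the first change on this oxygen that lies beyond the scatter, while the exchange of one aromatic group for another gave a 1.2-fold lower number from compound 2 to compound 3 (0.07 log units; within the scatter). This position therefore responds to at least one kind of change: the entering group has a six-membered non-aromatic ring and no hydrogen-bond donor, and it goes with the higher number. Nothing shown gives a cause for this step.

From the compounds shown here alone, since the ring type, the heavy-atom count and the donor count all change in this single step, their separate contributions remain open. Also open, going by these compounds, is how the number would move with a plain ethyl group or a phenyl group on the same oxygen.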